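Replacing Chloro with Methoxy on the Shared Core

A few compounds are considered here, and "the series" means these few. Any claim that something is new, unique, unknown or untested is made for them only; others in the source may bear on it.

Compound 1 `O=C1CNc2nc(Nc3ccc(F)cc3)ncc2N1`: in a functional assay on MDA-MB-468 cells (Homo sapiens) for cytotoxicity, read by MTT assay, with a stated time of 48 h (a higher number here means a weaker inhibitor, a lower number a stronger inhibitor), compound 1 gives > 100000 nM, which is a limit of the assay and not a number.
Compound 2 `O=C1CNc2nc(Nc3ccc(Cl)cc3)ncc2N1`: in this assay compound 2 gives 15000 nM.

Compound 2 therefore holds the only real number shown in this assay; the other value sits at the limit of > 100000 nM in this assay, at which 1 of the 2 values shown sits. Going by the values given here, the one measured step, an at least 6.6-fold lower number from compound 1 to compound 2 (0.82 log units; beyond the scatter), comes from chloro in place of fluoro on an aromatic carbon and is at least modest, so the group on that carbon can move the result beyond the scatter.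

Compound 3 `COc1ccc(Nc2ncc3c(n2)NCC(=O)N3)cc1` differs from compound 2 by methoxy in place of chloro on an aromatic carbon. Among the compounds with values here, no measured step covers methoxy, and the single step available only shows that this position matters, not which way a methoxy would push. The expectation is a weak inhibitor again, near compound 2 or somewhat weaker, with a wide range that reaches the limit of the assay. Compound 3 is estimated at 30000 nM, between 8000 nM and 100000 nM, which would mean a 2.0-fold higher number from compound 2 to compound 3 (0.30 log units; within the scatter) as the expected step.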

Compound 3, half-maximal inhibitory concentration: > 100000 nM
Compound 3: only a limit was reported; the forecaster's own chance of this, stated with the estimate: 30%; at least 3.3-fold (0.52 log units) between middle value and limit.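

In this assay, going by these compounds alone, chloro is now the only one of the three groups on this aromatic carbon that gives a real number. Methoxy in place of chloro gives an at least 6.6-fold higher number from compound 2 to compound 3 (0.82 log units; beyond the scatter), so a second change at this carbon also moves the result beyond the scatter, this time towards a weaker inhibitor, the same direction as going from chloro back to fluoro. Among these three compounds, then, activity depends on chloro being present, although a weak activity, and neither of the two other groups keeps it; compound 1 and compound 3 each stop at a limit of the assay rather than a number, so the step between them cannot be read, and the measured values show only this: the limit of > 100000 nM in this assay, at which 2 of the 3 values shown sit.

The three compounds do not show whether chloro is unusual here or whether a bromine atom, a methyl group or a trifluoromethyl group on the same carbon would also give a real number, perhaps a lower one. They also cannot explain why chloro differs from fluoro and methoxy, and they say nothing about moving the group elsewhere on the ring or changing the shared core.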